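The source may hold more compounds than are shown below. What is called first, only, known or untested is meant among the compounds shown, and "the series" means these compounds.

Working notes on the series. Compound 1 `O=C(CSc1nncnc1-c1ccccc1Cl)Nc1ccccn1`, compound 2 `O=C(CSc1nncnc1-c1ccccc1Cl)Nc1ccccc1[N+](=O)[O-]` and compound 3 `O=C(CSc1nncnc1-c1ccccc1Cl)Nc1cccnc1Cl` share one core and differ only in the group on the amide-type nitrogen. In an ADME assay on MT4 cells (Homo sapiens) for cytotoxicity, read by MTT assay (a lower number here means that less compound is tolerated, a higher number that more compound is tolerated), compound 1 gives 172000 nM, compound 2 gives 63000 nM and compound 3 gives 167000 nM. Compound 3 thus stands second highest of the three numbers, with compound 1 within the scatter of it and compound 2 as the furthest. The measured steps are a 2.7-fold lower number from compound 1 to compound 2 (0.44 log units; beyond the scatter), a 1.0-fold lower number from compound 1 to compound 3 (0.01 log units; within the scatter) and a 2.7-fold higher number from compound 2 to compound 3 (0.42 log units; beyond the scatter); only the nitrophenyl group moved the number beyond the scatter, and the swap between the two pyridinyl groups changed nothing.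

Compound 4 `Cc1cnc(NC(=O)CSc2nncnc2-c2ccccc2Cl)c(Br)c1` has not yet been measured in this assay. Its change from compound 3 is 3-bromo-5-methylpyridin-2-yl in place of 2-chloropyridin-3-yl on an amide-type nitrogen. Going by the values given here, the steps that bear on it are the aryl swaps above, which were at most modest, and the closest precedent, the pyridinyl-to-pyridinyl swap, stayed within the scatter. A small step at most is therefore expected, a 1.3-fold lower number from compound 3 to compound 4 (0.11 log units; within the scatter), with the direction uncertain. Compound 4 is estimated at 130000 nM, in the range 50000 nM to 260000 nM.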

Compound 4, half-maximal cytotoxic concentration: 144000 nM
Compound 4: middle estimate off by 1.1-fold (0.04 log units), on the low side; the range from low to high includes it.
By their numbers in this assay, from the lowest: compound 2; then compounds 4, 3 and 1 (each within the scatter of the next).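

In this assay the 3-bromo-5-methylpyridin-2-yl group on the amide-type nitrogen gives a 1.2-fold lower number from compound 3 to compound 4 (0.06 log units; within the scatter) and a 1.2-fold lower number from compound 1 to compound 4 (0.08 log units; within the scatter) so a pyridinyl group carrying both bromine and methyl stays within the scatter of the two earlier pyridinyl compounds. Going by these compounds alone, the separation from the nitrophenyl compound persists with a 2.3-fold higher number from compound 2 to compound 4 (0.36 log units; beyond the scatter) and compound 2 remains the only compound set apart from the other three. No measurement available here accounts for either the flat pyridinyl results or the lower number of compound 2.

Within the data shown here, with 2-nitrophenyl as the only non-pyridinyl group, the series cannot separate the contribution of the nitro group from that of the aromatic ring that carries it. Going by these compounds, it also remains open whether a plain phenyl group, an amine or carboxylic acid on the pyridinyl ring, or a longer chain on the amide-type nitrogen would move the number beyond the scatter.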